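Phenylpiperazine in Place of Triazolylthio on the Acetamide Chain

The compounds below may be only part of what the source reports. "The series", "measured", "known", "first", "only" and "open" are said of these compounds alone.

The measured compounds:
compound 1 `Cn1c(-c2ccc(NC(=O)CSc3nc4cc(Cl)ccc4o3)cc2)nc(-c2ccccc2)c1-c1ccccc1`: 20.6 ug/mL
compound 2 `Cn1cnnc1SCC(=O)Nc1ccc(-c2nc(-c3ccccc3)c(-c3ccccc3)n2C)cc1`: 10.7 ug/mL

Both compounds were tested in a functional assay on HT-29 cells (Homo sapiens) for cytotoxicity, read by MTT assay, with a stated time of 24 h; on this read-out lower numbers stand for stronger inhibition and higher numbers for weaker inhibition. Among the compounds with values here, compound 2 holds one of two numbers that sit within the scatter of each other; the only measured step, a 1.9-fold lower number from compound 1 to compound 2 (0.28 log units; within the scatter), exchanged one group on the sulfur of the acetamide chain and moved the number less than repeated measurements of this kind would. The two compounds therefore cannot be told apart on this read-out.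

Compound 3 `Cn1c(-c2ccc(NC(=O)CN3CCN(c4ccccc4)CC3)cc2)nc(-c2ccccc2)c1-c1ccccc1` has not been measured. It differs from compound 2 as follows: 4-phenylpiperazin-1-yl in place of (4-methyl-4H-1,2,4-triazol-3-yl)sulfanyl on a saturated chain carbon bound to a carbonyl carbon. Within the data shown here, the one measured step bears on this change only loosely: it shows that exchanging the group on the same chain carbon left the number inside the scatter, but no measured compound carries the entering group or lacks the sulfur. The step from compound 2 to compound 3 is therefore expected to fall within the scatter, a 1.1-fold higher number from compound 2 to compound 3 (0.05 log units; within the scatter), with a wide range. Compound 3 is estimated at 12 ug/mL, between 4 ug/mL and 40 ug/mL.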

Compound 3, half-maximal inhibitory concentration: 8.6 ug/mL
Compound 3: middle estimate off by 1.4-fold (0.14 log units), on the high side, within the range that was stated.
By their numbers in this assay, from the lowest: compounds 3, 2 and 1 (each within the scatter of the next, the first and the last beyond it).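

In this assay, the sulfur on the saturated chain carbon bound to a carbonyl carbon turns out not to be required for a number in this range: the exchange gives a 1.2-fold lower number from compound 2 to compound 3 (0.09 log units; within the scatter) and so leaves 4-phenylpiperazin-1-yl indistinguishable from (4-methyl-4H-1,2,4-triazol-3-yl)sulfanyl on this read-out, even though the entering group has no sulfur and no five-membered aromatic ring. Set against (5-chloro-1,3-benzoxazol-2-yl)sulfanyl, the same entering group gives a 2.4-fold lower number from compound 1 to compound 3 (0.38 log units; beyond the scatter) and thus the first step at this position to clear the scatter, though only modestly, and compound 2 remains within the scatter of both other compounds. Nothing available explains either step.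

Going by these compounds, it remains open whether the terminal phenyl of the piperazine contributes at all, and whether a plain morpholine, a 4-methylpiperazine or a longer chain carrying the same 4-phenylpiperazin-1-yl would keep the number in this range. On these data alone, all three compounds share one core, so how 4-phenylpiperazin-1-yl behaves on any other core also remains unknown.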